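This account rests on a few compounds, and the source may have more. Where it says the series, first, only, none or still open, it means among the compounds named here.

Measured so far in a functional assay on SW480 cells (Homo sapiens) for cytotoxicity, read by MTT assay, with a stated time of 24 h; a lower number here means a stronger inhibitor, a higher number a weaker inhibitor:
Compound 1 `C=CC1=C(C(=O)NCc2ccc(C)cc2)C(c2ccc(F)cc2)OC1` gives > 100000 nM, a limit of the assay.
Compound 2 `C=CC1=C(C(=O)NC(C)(C)C)C(c2ccc(OC)cc2)OC1` gives > 100000 nM, likewise a limit.
Compound 3 `C=CC1=C(C(=O)NC(C)(C)C)C(c2ccc(F)cc2)OC1` gives > 100000 nM, again a limit.

Compound 2 thus stands only at a limit, and the whole set so far sits at the limit of > 100000 nM in this assay, at which 3 of the 3 values shown sit. The two steps that reach compound 3, a step that the two limits leave unreadable from compound 1 to compound 3 and a step that the two limits leave unreadable from compound 2 to compound 3, are unreadable between limits and give no measure of the amide substituent or the aromatic substituent in this assay. Compound 4 `C=CC1=C(C(=O)NC2CCCCC2)C(c2ccc(OC)cc2)OC1` differs from compound 2 by cyclohexyl in place of tert-butyl on an amide-type nitrogen. Going by the values given here, no measured step bears on this change, and no number has yet emerged, so compound 4 is expected to stay at the limit, the expected step being a number no higher from compound 2 to compound 4 (the limit leaves the size open). The estimate for compound 4 is 100000 nM, with a range from 40000 nM to 300000 nM.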

Compound 4, half-maximal inhibitory concentration: > 100000 nM
Compound 4 ended at the assay's limit; the forecaster's own chance of this, stated with the estimate: 85%; the middle value lies on the limit itself.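

Compound 4 gives > 100000 nM, a limit of the assay. Compound 2 gives > 100000 nM, also a limit, so the change between these two compounds cannot be read as a step. The compounds shown leave open whether any amide or aromatic substituent gives a measurable value.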